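A few compounds are considered here, and "the series" means these few. Any claim that something is new, unique, unknown or untested is made for them only; others in the source may bear on it.

Measured so far:

- compound 1 `CC1=C(N2CC2)C(=O)C(CC(C)OC(N)=O)=C(N2CC2)C1=O`: 5.18
- compound 2 `CC1=C(N2CC2)C(=O)C(CCCOC(N)=O)=C(N2CC2)C1=O`: 5.48
- compound 3 `CC1=C(N2CC2)C(=O)C(C(C)COC(N)=O)=C(N2CC2)C1=O`: 5.31

These three share one core and differ only in the carbamate-bearing side chain. In a functional assay on L1210 cells (Mus musculus), with a stated time of 1 days (on this read-out lower numbers stand for lower potency and higher numbers for higher potency (the scale is a negative logarithm)), compound 3 stands second highest of the three, but its neighbours lie within the scatter on either side: a number 0.13 log units higher from compound 1 to compound 3 (within the scatter) and a number 0.17 log units lower from compound 2 to compound 3 (within the scatter). The remaining comparison, a number 0.30 log units higher from compound 1 to compound 2 (within the scatter), is also within the scatter, so the three side chains cannot be told apart on these numbers.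

Compound 4 `CC1=C(N2CC2)C(=O)C(N2CC2)=C(N2CC2)C1=O` takes a different kind of step. Compared with compound 3, (a group of 3 heavy atoms (2 carbon, 1 nitrogen; one three-membered non-aromatic ring with 1 hetero atom) in place of a group of 7 heavy atoms (4 carbon, 1 nitrogen, 2 oxygen; no ring), on a double-bonded ring carbon). Among the measured compounds shown here, none of the measured steps bears on this change: each of them exchanged one carbamate-bearing chain for another, and all stayed within the scatter. For the measured compounds named here, there is therefore no measured step that tells how this assay responds when the whole side chain is exchanged for a third aziridin-1-yl group, and the expectation must stay wide. The step from compound 3 to compound 4 is expected to be a number 0.39 log units higher from compound 3 to compound 4 (beyond the scatter), and compound 4 is estimated at 5.7, with a range from 4.9 to 6.5.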

Compound 4, logarithm of the reciprocal of the active concentration, log(1/C): 5.69
Estimate against measurement, compound 4: 0.01 log units above; the measured number falls inside the stated range.
By their numbers in this assay, from the lowest: compounds 1, 3, 2 and 4 (each within the scatter of the next, the first and the last beyond it).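

Earlier steps only exchanged one carbamate-bearing chain for another. Here the whole chain on the double-bonded ring carbon gives way to an aziridin-1-yl group, and compound 4 keeps its activity in this assay, so with this core the carbamate is not needed for a reading in this range. The exchange reaches beyond the scatter against two of the chains, with a number 0.38 log units higher from compound 3 to compound 4 (beyond the scatter) and a number 0.51 log units higher from compound 1 to compound 4 (beyond the scatter), but compound 2 goes against this picture, with a number 0.21 log units higher from compound 2 to compound 4 (within the scatter); no measured evidence accounts for these differences.

The compounds shown leave open whether the aziridin-1-yl ring itself matters at this position, or whether an open-chain amine such as dimethylamino would read the same. They also leave open how a hydroxypropyl chain, without the carbamate, would compare.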